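Furan-3-yl in Place of Phenyl on the Shared Core

The source may hold more compounds than are shown below. What is called first, only, known or untested is meant among the compounds shown, and "the series" means these compounds.

In a functional assay on K562 cells (Homo sapiens), read by MTT assay, with a stated time of 72 h (on this read-out lower numbers stand for stronger inhibition and higher numbers for weaker inhibition), compound 3 `CNc1ncnc2c1c(-c1ccccc1)cn2[C@@H]1O[C@H](CO)[C@@H](O)[C@H]1O` gives only a limit, > 20000 nM. Compound 2 `CNc1ncnc2c1c(I)cn2[C@@H]1O[C@H](CO)[C@@H](O)[C@H]1O` likewise gives only a limit in this assay, > 100000 nM. The step that the two limits leave unreadable from compound 2 to compound 3 therefore cannot be read, both ends being limits. Compound 1 `CN(C)c1ncnc2c1c(-c1ccoc1)cn2[C@@H]1O[C@H](CO)[C@@H](O)[C@H]1O` gives 1540 nM in this assay. Compound 4 `CNc1ncnc2c1c(-c1ccoc1)cn2[C@@H]1O[C@H](CO)[C@@H](O)[C@H]1O` is not yet measured; it differs from compound 3 by furan-3-yl in place of phenyl on an aromatic carbon. Among the measured compounds shown here, no measured step covers this exchange directly. Compound 1 carries the same furan-3-yl group but differs from compound 4 in the group on the pyrimidine side, so its value serves only as a rough pointer. The step of an at least 5.0-fold lower number from compound 3 to compound 4 (0.69 log units; beyond the scatter) is expected to bring the number off the limit. Compound 4 is estimated at 4000 nM, within 800 nM to 30000 nM.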

Compound 4, half-maximal inhibitory concentration: > 20000 nM
Compound 4: no number, only a limit (the forecaster's own chance of this, stated with the estimate: 30%); middle value at least 5.0-fold (0.69 log units) from the limit.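

With furan-3-yl in place of phenyl, compound 4 stays at a limit in this assay, so the steps to it from compound 2 and from compound 3 cannot be read. The nitrogen on the shared core now stands out: with furan-3-yl held fixed, hydrogen in place of methyl gives an at least 12-fold higher number from compound 1 to compound 4 (1.11 log units; beyond the scatter), a large step. Compound 4 shares its limit with compound 3: the limit of > 20000 nM in this assay, at which 2 of the 4 values shown sit.

Left open is whether a second methyl on that nitrogen has the same effect with phenyl or iodo on the aromatic carbon. Also open, from the compounds shown here alone, is whether an ethyl group on that nitrogen, or pyridin-3-yl on the aromatic carbon, would give a readable number.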